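Two Curcumin-like Dihydropyrimidinones and a Dichlorophenyl Variant

A few compounds are considered here, and "the series" means these few. Any claim that something is new, unique, unknown or untested is made for them only; others in the source may bear on it.

Compound 1 `COc1cc(/C=C/C(=O)C2=C(/C=C/c3ccc(O)c(OC)c3)NC(=O)NC2c2ccc(O)cc2)ccc1O` and compound 2 `COc1cc(/C=C/C(=O)C2=C(/C=C/c3ccc(O)c(OC)c3)NC(=S)NC2c2ccccc2O)ccc1O` share a core that carries two methoxyphenol-bearing arms. In a functional assay, with a stated time of 20 min, tested at 50 uM (on this read-out lower numbers stand for a weaker effect and higher numbers for a stronger effect at the one concentration tested), compound 1 gives 86.2%, and in the same test compound 2 gives 88.5%. Compound 2 thus holds the higher of the two numbers, but the gap to compound 1 is within the usual scatter, so the two cannot be told apart.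

Compound 3 `COc1cc(/C=C/C(=O)C2=C(/C=C/c3ccc(O)c(OC)c3)NC(=S)NC2c2c(Cl)cccc2Cl)ccc1O` differs from compound 2 in a single place: 2,6-dichlorophenyl in place of 2-hydroxyphenyl on a saturated ring carbon. Among the measured compounds shown here, no pair of measured compounds shows what such a change does in this assay, and the two numbers at hand sit close together, so the only expectation that can be drawn from them is a step in this assay of no size beyond the scatter, in either direction. The step from compound 2 to compound 3 is therefore estimated as a number 3.5 percentage points lower from compound 2 to compound 3 (within the scatter). Compound 3 is expected to give 85% in this assay, with a likely range from 70% to 95%.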

Compound 3, a percentage reported as activity, at one concentration (the size of the read-out at that concentration, not a potency): 50%
Compound 3: the middle estimate sits 35 percentage points above what was measured, outside the stated range (below it).
By their numbers in this assay, from the lowest: compound 3; then compounds 1 and 2 (each within the scatter of the next).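

In this assay, putting 2,6-dichlorophenyl in place of 2-hydroxyphenyl on the saturated ring carbon gives a number 38.5 percentage points lower from compound 2 to compound 3 (beyond the scatter). This shows that the read-out depends strongly on the group at this position, something compounds 1 and 2, which both carry a hydroxyl-bearing phenyl group here, could not reveal. Nothing measured here gives a reason for this step.

The change removes the hydroxyl group and adds two chlorines in one move, so the compounds shown leave open which of these matters, or whether both do. A plain phenyl group or a phenyl group carrying a single chlorine at this position would help separate the two, and a methoxyphenyl group would show how the read-out responds when the hydroxyl hydrogen is replaced by a methyl group.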